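The source may report more compounds than this note shows. Statements on the series, on what has been measured and on what is new or still open speak of the compounds shown alone.

Compound 2 `COc1cc(-c2c(-c3ccc4[nH]ccc4c3)c(=O)c2=O)cc(OC)c1OC` gives 6 nM in a functional assay on HepG2 cells (Homo sapiens) for inhibition, read by MTT assay, with a stated time of 72 h (on this read-out lower numbers stand for stronger inhibition and higher numbers for weaker inhibition), level with compound 1 `COc1cc(-c2c(-c3ccc4cc[nH]c4c3)c(=O)c2=O)cc(OC)c1OC`, which in this assay gives 6 nM; the step of no change at the digits printed from compound 1 to compound 2 (within the scatter) lies within the scatter. Compound 3 `COc1ccc(-c2c(-c3cc(OC)c(OC)c(OC)c3)c(=O)c2=O)cc1N` carries the change (3-amino-4-methoxyphenyl in place of 1H-indol-5-yl on an aromatic carbon). Among the measured compounds shown here, the only measured step, from compound 1 to compound 2, exchanges one indolyl for another and so says nothing direct about setting a 3-amino-4-methoxyphenyl in place of the 1H-indol-5-yl; it shows only that the shared core tolerated that earlier exchange without a change beyond the scatter. For the measured compounds named here, with no closer precedent, the step of a 1.7-fold higher number from compound 2 to compound 3 (0.22 log units; within the scatter) is expected to be small, with no firm direction, and the range is left wide to reflect the lack of a guiding step. Compound 3 is therefore estimated at 10 nM in this assay, between 2 nM and 60 nM.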

Compound 3, half-maximal inhibitory concentration: 5 nM
Estimate against measurement, compound 3: 2.0-fold (0.30 log units) above; low and high end bracket the measured number.
By their numbers in this assay, from the lowest: compounds 3, 1 and 2 (each within the scatter of the next).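

In this assay, setting 3-amino-4-methoxyphenyl in place of 1H-indol-5-yl gives a 1.2-fold lower number from compound 2 to compound 3 (0.08 log units; within the scatter), and setting it in place of 1H-indol-6-yl gives a 1.2-fold lower number from compound 1 to compound 3 (0.08 log units; within the scatter). The earlier pair had exchanged only one indolyl for another, whereas these steps show that this position, on an aromatic carbon of a four-membered aromatic ring of carbon only, also takes a group with a single six-membered aromatic ring and no five-membered aromatic ring, with no change beyond the scatter. Nothing available explains this result. The compounds shown leave open what the amino and methoxy groups each contribute, since no phenyl group carrying only one of them appears among them. They also leave open whether a hydroxyl group or a carboxylic acid in place of the amine would keep the reading at this level.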